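Swapping the 4-chlorophenyl group of compound 1

This account rests on a few compounds, and the source may have more. Where it says the series, first, only, none or still open, it means among the compounds named here.

Values in a functional assay on the whole organism (Hindlimb, strain albino) with Mus musculus as the target, in the maximal electroshock model, with a stated time of 0.5 h; a lower number here means that less compound is needed, a higher number that more compound is needed for the effect:
compound 1 (`O=C(/C=C/c1ccc(Cl)cc1)Nc1nc2ccc(Cl)cc2s1`) gives 204 umol/kg
compound 2 (`COc1ccc(/C=C/C(=O)Nc2nc3ccc(Cl)cc3s2)cc1`) gives 259 umol/kg
compound 3 (`Cc1ccc2nc(NC(=O)/C=C/c3ccc(Cl)cc3)sc2c1`) gives 152 umol/kg

Compound 1 stands level with compound 2 and compound 3, with both of its steps inside the scatter. Compound 4 (`O=C(/C=C/OC1=CC=C1)Nc1nc2ccc(Cl)cc2s1`) differs from it by a larger change: a group of 5 heavy atoms (4 carbon, 1 oxygen; one four-membered non-aromatic ring of carbon only) in place of a group of 7 heavy atoms (6 carbon, 1 chlorine; one six-membered aromatic ring of carbon only), on a double-bonded chain carbon bound to a double-bonded chain carbon. Within the data shown here, only two measured steps bear on this: a 1.3-fold higher number from compound 1 to compound 2 (0.10 log units; within the scatter) for methoxy in place of chloro, and a 1.3-fold lower number from compound 1 to compound 3 (0.13 log units; within the scatter) for methyl in place of chloro. Neither replaces a whole 4-chlorophenyl group, and neither points in a clear direction, so no step beyond the scatter is expected in this assay, though this guide is weak. The estimated step is a 1.1-fold higher number from compound 1 to compound 4 (0.03 log units; within the scatter), with a wide range around it. The expected value for compound 4 is 220 umol/kg, estimated to lie from 90 umol/kg to 550 umol/kg.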

Compound 4, dose for half-maximal effect: 544 umol/kg
Beside the measured number, compound 4's estimate is 2.5-fold (0.39 log units) below it, and the stated range covers the measured number.
By their numbers in this assay, from the lowest: compounds 3, 1 and 2 (each within the scatter of the next); then compound 4.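

In this assay, among these compounds, the step of a 2.7-fold higher number from compound 1 to compound 4 (0.43 log units; beyond the scatter) is the first here to go beyond the scatter. Compound 2 changed only the chloro on the 4-chlorophenyl group, with a step within the scatter, whereas compound 4 replaces that whole group, so this place on the chain tolerates less when the entire group is exchanged. Nothing measured here explains the step.

The compounds shown cannot separate losing the 4-chlorophenyl group from gaining the new group. A plain phenyl or an amine at this place would help tell those two apart.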